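Removing the Core Methyl: Expectation for Compound 3

A few compounds are considered here, and "the series" means these few. Any claim that something is new, unique, unknown or untested is made for them only; others in the source may bear on it.

Compound 1 `CCOC(=O)N1CCC(Oc2ncnc(Oc3ccc(/C=C4\SC(=O)NC4=O)cc3)c2C)CC1`: 157 nM
Compound 2 `Cc1c(Oc2ccc(/C=C3\SC(=O)NC3=O)cc2)ncnc1OC1CCN(C(=O)OCc2ccccc2)CC1`: 805 nM

In a functional assay on CHO-K1 cells for agonist activity at Glucose-dependent insulinotropic receptor (Homo sapiens), read by cAMP accumulation and immunoassay, with a stated time of 1 h (on this read-out higher numbers stand for an effect only at larger amounts of compound and lower numbers for an effect already at smaller amounts), compound 1 gives 157 nM, the lowest of the two numbers shown. Compound 2 gives 805 nM, and the change from compound 1 to compound 2 brings a 5.1-fold higher number from compound 1 to compound 2 (0.71 log units; beyond the scatter).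

Compound 3 `CCOC(=O)N1CCC(Oc2cc(Oc3ccc(/C=C4\SC(=O)NC4=O)cc3)ncn2)CC1` differs from compound 1 by hydrogen in place of methyl on an aromatic carbon. Going by the values given here, neither measured step bears on this change: the one measured step concerns a different part of the molecule, away from the core. The expectation therefore rests on compound 1 alone, with a modest step toward higher numbers expected, a 2.5-fold higher number from compound 1 to compound 3 (0.41 log units; beyond the scatter). Compound 3 is expected to give 400 nM, within 120 nM to 1300 nM.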

Compound 3, half-maximal effective concentration: 790 nM
Compound 3: middle estimate off by 2.0-fold (0.30 log units), on the low side; low and high end bracket the measured number.
By their numbers in this assay, from the lowest: compound 1; then compounds 3 and 2 (each within the scatter of the next).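

Replacing the methyl with hydrogen brings a 5.0-fold higher number from compound 1 to compound 3 (0.70 log units; beyond the scatter) in this assay and so shows that the core itself, not only the far end of the molecule, affects this number. The loss of a single carbon, at a position ortho to two large groups, is enough to move the result beyond the usual scatter. Nothing available here explains this shift.

On these data alone, whether an ethyl group or a chlorine atom on this carbon would give lower or higher numbers remains open. So does whether removing the methyl from compound 2 would have a similar effect.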